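The source may report more compounds than this note shows. Statements on the series, on what has been measured and on what is new or still open speak of the compounds shown alone.

In a functional assay on MCF7 cells (Homo sapiens) for cytotoxicity (on this read-out higher numbers stand for weaker inhibition and lower numbers for stronger inhibition), three compounds sharing one core differ only in the ring on a saturated chain carbon bound to an aromatic nitrogen. Compound 1 `COc1ccc(Cn2nc(Nc3cc(C)[nH]n3)c3ccccc3c2=O)cc1` carries 4-methoxyphenyl there, and its > 30000 nM is a limit of the assay. Compound 2 `Cc1cc(Nc2nn(Cc3cccnc3)c(=O)c3ccccc23)n[nH]1`, with pyridin-3-yl, gives a true number of 13400 nM. Compound 3 `Cc1cc(Nc2nn(Cc3ccncc3)c(=O)c3ccccc23)n[nH]1`, with pyridin-4-yl, stands at > 30000 nM, which is again only a limit.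

The first swap gave an at least 2.2-fold lower number from compound 1 to compound 2 (0.35 log units; beyond the scatter). Moving to pyridin-4-yl gave an at least 2.2-fold higher number from compound 2 to compound 3 (0.35 log units; beyond the scatter). The remaining pair shows a step that the two limits leave unreadable from compound 1 to compound 3.

Compound 4 `Cc1cc(Nc2nn(Cc3csc(C)n3)c(=O)c3ccccc23)n[nH]1` changes the same place: 2-methyl-1,3-thiazol-4-yl in place of pyridin-4-yl on a saturated chain carbon bound to an aromatic nitrogen. Here 2-methyl-1,3-thiazol-4-yl stands in place of pyridin-4-yl. Within the data shown here, no measured compound carries this ring, so the three steps above bear on the change only indirectly. They show that swaps at this place can move the read-out modestly, and that it can stay at the limit. Among the measured compounds shown here, compound 2, at 13400 nM, is the only measured compound with a true number, so a modest shift towards lower numbers is the most that is expected. The expected change is an at least 1.3-fold lower number from compound 3 to compound 4 (0.13 log units; that floor lies within the scatter). Compound 4 is estimated at 22000 nM, with an expected range from 9000 nM to 45000 nM.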

Compound 4, half-maximal inhibitory concentration: > 30000 nM
Compound 4 was reported as a limit; the forecaster's own chance of this, stated with the estimate: 55%; middle value at least 1.3-fold (0.13 log units) from the limit.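

In this assay, the swap from pyridin-3-yl to 2-methyl-1,3-thiazol-4-yl gave an at least 2.2-fold higher number from compound 2 to compound 4 (0.35 log units; beyond the scatter), so a five-membered aromatic ring with 2 hetero atoms did not keep the true number seen with compound 2. Among these compounds, the value of compound 4 is a limit and not a number, and pyridin-3-yl remains the only one of the four rings at this place to give a true number, while the other three sit at the same limit: the limit of > 30000 nM in this assay, at which 3 of the 4 values shown sit. The steps from compound 1 and from compound 3 to compound 4 cannot be read, as each joins two limits.

From the compounds shown here alone, how far compound 1, compound 3 and compound 4 lie beyond that limit stays open, so no order among their three rings can be given. Also open, going by these compounds, is whether a pyridin-2-yl ring, a 1,3-thiazol-4-yl ring without the methyl group, or a longer chain carrying pyridin-3-yl would give a true number in this assay.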